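The compounds below may be only part of what the source reports. "The series", "measured", "known", "first", "only" and "open" are said of these compounds alone.

In a functional assay on SK-N-SH cells (Homo sapiens) for inhibition, read by MTT assay, with a stated time of 72 h, tested at 30 uM (on this read-out higher numbers stand for more inhibition of growth at the one concentration tested and lower numbers for less inhibition of growth), compound 1 (`C=CCc1ccc(OCc2cn(-c3cccc([N+](=O)[O-])c3)nn2)c(O)c1`) gives 31.1% and compound 2 (`C=CCc1ccc(OCc2cn(-c3ccccc3CO)nn2)c(O)c1`) gives 12.9% as the lower of the two numbers, a gap beyond the usual scatter. Compound 3 (`C=CCc1ccc(OCc2cn(-c3cccc(C#N)c3)nn2)c(O)c1`) carries 3-cyanophenyl in place of 2-(hydroxymethyl)phenyl on an aromatic nitrogen. Among the measured compounds shown here, no measured pair shows this change directly. Compound 1 at 31.1% also lacks 2-(hydroxymethyl)phenyl, so a rise in this assay is expected, though perhaps not far beyond the scatter. The estimated step is a number 11.1 percentage points higher from compound 2 to compound 3 (beyond the scatter) in that direction. For compound 3 the expected value is 24% within an estimated range of 11% to 38% in this measurement.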

Compound 3, percent growth inhibition at one concentration: 21.2%
Compound 3: middle estimate off by 2.8 percentage points, on the high side; the measured number falls inside the stated range.
By their numbers in this assay, from the lowest: compounds 2, 3 and 1 (each within the scatter of the next, the first and the last beyond it).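

In this assay, 3-cyanophenyl in place of 2-(hydroxymethyl)phenyl on the aromatic nitrogen gives a number 8.3 percentage points higher from compound 2 to compound 3 (within the scatter), so this exchange does not separate the two compounds. Cyano in place of nitro on an aromatic carbon gives a number 9.9 percentage points lower from compound 1 to compound 3 (within the scatter), so at this position the nitrile and the nitro group cannot be told apart either. No independent measurement bears on these results. Still open, going by these compounds, is whether an amine or a carboxylic acid on that phenyl ring, or a longer chain in its place, would shift growth inhibition beyond the scatter.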